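From a Pyridinyl Sulfide to a Phenyl Ether

The compounds below may be only part of what the source reports. "The series", "measured", "known", "first", "only" and "open" are said of these compounds alone.

Measured compounds:
compound 1 `COc1ccc(CN(C(=O)CSc2nnnn2C)c2cc(OC)c(OC)c(OC)c2)cc1`, 10500 nM
compound 2 `COc1ccc(CN(C(=O)COc2ccc(OC)cc2)c2cc(OC)c(OC)c(OC)c2)cc1`, 66400 nM
compound 3 `COc1ccc(CN(C(=O)CSc2ccccn2)c2cc(OC)c(OC)c(OC)c2)cc1`, 7510 nM

In a functional assay on PC-3 cells (Homo sapiens) for antiproliferative activity, read by MTT assay, with a stated time of 48 h (on this read-out higher numbers stand for weaker inhibition and lower numbers for stronger inhibition), compound 3 gives the lowest of the three numbers. Its nearest neighbour is compound 1, and that gap is within the scatter, as a 1.4-fold lower number from compound 1 to compound 3 (0.15 log units; within the scatter) shows; its furthest is compound 2, as an 8.8-fold lower number from compound 2 to compound 3 (0.95 log units; beyond the scatter) shows. Compound 4 `COc1ccc(CN(C(=O)COc2ccccc2)c2cc(OC)c(OC)c(OC)c2)cc1` is reached from compound 3 by a single change at the saturated chain carbon bound to the carbonyl carbon: phenoxy in place of (pyridin-2-yl)sulfanyl on a saturated chain carbon bound to a carbonyl carbon.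

Among the measured compounds shown here, two measured steps bear on this. The step of an 8.8-fold lower number from compound 2 to compound 3 (0.95 log units; beyond the scatter) is the closest comparison, run in reverse: there an aryl ether at this carbon gave a clearly higher number than the pyridinyl sulfide. The step of a 6.3-fold higher number from compound 1 to compound 2 (0.80 log units; beyond the scatter) points the same way for the other sulfide. For the measured compounds named here, compound 4 lacks the methoxy group of compound 2, and no measured step covers that difference, so the expected increase is set somewhat smaller than the reversal of the measured step.

Compound 4 is therefore expected to show a higher number, estimated as a 5.3-fold higher number from compound 3 to compound 4 (0.73 log units; beyond the scatter). The estimate for compound 4 is 40000 nM, with a range from 12000 nM to 130000 nM.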

Compound 4, half-maximal inhibitory concentration: 19700 nM
For compound 4 the middle estimate is 2.0-fold (0.31 log units) above the measured one, and the stated range covers the measured number.
By their numbers in this assay, from the lowest: compounds 3, 1 and 4 (each within the scatter of the next, the first and the last beyond it); then compound 2.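

In this assay, the phenoxy group on the saturated chain carbon bound to a carbonyl carbon still reads weaker than the (pyridin-2-yl)sulfanyl group, with a 2.6-fold higher number from compound 3 to compound 4 (0.42 log units; beyond the scatter), but the methoxy group of compound 2 turns out to carry part of that earlier aryl ether gap: with hydrogen in place of methoxy on an aromatic carbon, the result is a 3.4-fold lower number from compound 2 to compound 4 (0.53 log units; beyond the scatter). Against the other sulfide the ether does not separate at all, as a 1.9-fold higher number from compound 1 to compound 4 (0.27 log units; within the scatter) shows, so the preference for sulfide over ether holds for the pair of compound 3 and compound 4 but not for the pair of compound 1 and compound 4, which goes against it. No evidence is at hand on what lies behind any of these steps.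

The step to compound 4 changes the sulfur and the ring nitrogen together, and a pyridin-2-yloxy or a phenylsulfanyl group at this carbon would tell the two apart. Also open, as far as these compounds go, is how the phenoxy ring would read in this assay with an amine or a carboxylic acid in place of the methoxy group.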